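The source may report more compounds than this note shows. Statements on the series, on what has been measured and on what is new or still open speak of the compounds shown alone.

Compound 1, with the structure `COc1cc2c(cc1OC)CN(CC(=O)Nc1ccc3c(c1)/C(=C/c1cccs1)C(=O)N3)CC2`, is tested in a functional assay on A549 cells (Homo sapiens) for cytotoxicity, with a stated time of 72 h (a lower number here means a stronger inhibitor, a higher number a weaker inhibitor), where compound 1 gives 660 nM. That is the lower of the two numbers recorded so far. The other measured compound is compound 2, with the structure `COc1cc2c(cc1OC)CN(CC(=O)Nc1ccc3c(c1)/C(=C\c1nccn1C)C(=O)N3)CC2`; in this assay compound 2 gives 2750 nM, a number that stands beyond the usual scatter above that of compound 1. The compound that follows is compound 3, with the structure `COc1cc2c(cc1OC)CN(CC(=O)Nc1ccc3c(c1)/C(=C/c1cnc[nH]1)C(=O)N3)CC2`. It differs from compound 1 in one place: 1H-imidazol-5-yl in place of thiophen-2-yl on a double-bonded chain carbon bound to a double-bonded ring carbon. Among the compounds with values here, no measured pair shows this exact change, so the size of the step can only be estimated. Given that compound 2, the one other compound with a nitrogen-containing ring in that place, gives 2750 nM, compound 3 is expected to give a higher number than compound 1, with a step of a 2.3-fold higher number from compound 1 to compound 3 (0.36 log units; beyond the scatter). Compound 3 is therefore estimated at 1500 nM, within a range from 500 nM to 4500 nM.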

Compound 3, half-maximal inhibitory concentration: 2190 nM
Estimate against measurement, compound 3: 1.5-fold (0.16 log units) below, and the stated range covers the measured number.
By their numbers in this assay, from the lowest: compound 1; then compounds 3 and 2 (each within the scatter of the next).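

Within the data shown here, replacing thiophen-2-yl with 1H-imidazol-5-yl on a double-bonded chain carbon bound to a double-bonded ring carbon gives a 3.3-fold higher number from compound 1 to compound 3 (0.52 log units; beyond the scatter) in this assay, the first direct reading of a single change at this position. The two groups have the same heavy-atom count, yet they differ in their ring hetero atoms and in the hydrogen-bond donor carried by 1H-imidazol-5-yl, so the number at this position moves even when the size of the group by that count does not. No measurement shown here accounts for the step.

The compounds shown leave open whether the ring nitrogens or the hydrogen-bond donor of 1H-imidazol-5-yl goes with the higher number. Nor do they show how a phenyl, furan-2-yl or pyridin-3-yl ring in the same place would compare with thiophen-2-yl.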